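The compounds below may be only part of what the source reports. "The series", "measured", "known", "first", "only" and "open" are said of these compounds alone.

The measured compounds:
compound 1, `O=C(CI)NCc1cn([C@H]2C[C@H](O)[C@@H](CO)O2)c(=O)[nH]c1=O`, gives 107000 nM in an ADME assay on L1210/0 cells (Mus musculus) for cytotoxicity, with a stated time of 48 h; on this read-out lower numbers stand for stronger inhibition and higher numbers for weaker inhibition
compound 2, `CC1(C)[C@@H](CO)CC[C@@]1(C)Cn1cnc2c(N)ncnc21`, gives > 200000 nM, which is a limit of the assay and not a number
compound 3, `CC1(C)C(CO)CC1Cn1cnc2c(Cl)nc(N)nc21`, gives > 200000 nM, likewise a limit and not a number

Compound 1 is therefore the only one of the three to return a number in this assay; compound 2 and compound 3 sit at the limit of > 200000 nM in this assay, at which 2 of the 3 values shown sit. Compound 1 stands alone, and its value is the single anchor for what follows.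

Compound 4, `CCCCCC#Cc1cn([C@H]2C[C@H](O)[C@@H](CO)O2)c(=O)[nH]c1=O`, has not yet been tested in this assay. It differs from compound 1 in one place: hept-1-yn-1-yl in place of (((iodomethyl)carbonyl)amino)methyl on an aromatic carbon. For the measured compounds named here, no step between two measured compounds exists to calibrate this change, since the other two values are limits, so the expectation rests on compound 1 alone together with the nature of the exchange, in which a chain carrying a hydrogen-bond donor and acceptor gives way to a chain of seven carbons with a triple bond.

Compound 4 is expected to gain modestly, a step of a 3.6-fold lower number from compound 1 to compound 4 (0.55 log units; beyond the scatter) in this assay, beyond the scatter though not by a wide margin. The estimate for compound 4 is 30000 nM, with an expected range from 5000 nM to 180000 nM.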

Compound 4, half-maximal inhibitory concentration: > 200000 nM
Compound 4 was reported as a limit; the forecaster's own chance of this, stated with the estimate: 20%; middle value at least 6.6-fold (0.82 log units) away from the limit.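

In this assay compound 4 gives > 200000 nM, which is a limit of the assay and not a number. Putting hept-1-yn-1-yl in place of (((iodomethyl)carbonyl)amino)methyl on this aromatic carbon gives an at least 1.8-fold higher number from compound 1 to compound 4 (0.27 log units; that floor lies within the scatter), so a loss cannot be claimed, but the change brings no gain here, which compound 1 alone could not have shown. Compound 1 remains the only one of the four compounds to return a number: the limit of > 200000 nM in this assay, at which 3 of the 4 values shown sit.

Going by these compounds, how far compound 4 lies past the limit stays open, and with it the true size of this step. Also open, on these data alone, is whether the number of compound 1 depends on the iodomethyl end of its chain, and whether a shorter alkyne such as prop-1-yn-1-yl, or a chain ending in an amine or a carboxylic acid, would return a number on this carbon of the shared core.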